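Aryl change on the sulfonamide nitrogen: working notes

The source may report more compounds than this note shows. Statements on the series, on what has been measured and on what is new or still open speak of the compounds shown alone.

Of the compounds shown here, three sharing one core have been read so far in a functional assay on MCF7 cells (Homo sapiens) for antiproliferative activity, read by sulforhodamine B assay, with a stated time of 48 h; on this read-out higher numbers stand for weaker inhibition and lower numbers for stronger inhibition. Compound 2 `O=C1NCCN1c1ccc(S(=O)(=O)Nc2ccc(F)c(F)c2)cc1` gives 620 nM. Compound 3 `COc1ccc(NS(=O)(=O)c2ccc(N3CCNC3=O)cc2)cc1OC` gives 610 nM, and these two values lie within the scatter of each other, so compound 2 stands level with compound 3 on the numbers available. Compound 1 `CCCCCCCc1ccc(NS(=O)(=O)c2ccc(N3CCNC3=O)cc2)cc1` gives > 1000 nM, which is a limit of the assay and not a number.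

Compound 4 `Cc1cccc(NS(=O)(=O)c2ccc(N3CCNC3=O)cc2)c1C` has not yet been measured. It differs from compound 2 by one change on the sulfonamide nitrogen, with 2,3-dimethylphenyl in place of 3,4-difluorophenyl on a sulfonamide nitrogen. Among the compounds with values here, no measured pair isolates a single change, so any expectation here rests on thin ground. Different aryl groups still give close values in compound 2 at 620 nM and compound 3 at 610 nM, and on that basis no change beyond the scatter is expected. Compound 1 does not join this pair, so a weaker result remains possible.

The step expected in this assay is a 1.1-fold lower number from compound 2 to compound 4 (0.05 log units; within the scatter), a small move toward a lower number that would stay within the scatter. The estimated value for compound 4 is 550 nM, with an expected range of 220 nM to 1000 nM.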

Compound 4, half-maximal inhibitory concentration: 230 nM
The estimate for compound 4 lay 2.4-fold (0.38 log units) above the measured number; the measured number falls inside the stated range.
By their numbers in this assay, from the lowest: compound 4; then compounds 3 and 2 (each within the scatter of the next). At a limit, above all of these: compound 1.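

In this assay, the aryl group on the sulfonamide nitrogen now has a single-change comparison: 2,3-dimethylphenyl in place of 3,4-difluorophenyl gives a 2.7-fold lower number from compound 2 to compound 4 (0.43 log units; beyond the scatter). Compounds 2 and 3 alone, with different aryl groups and values within the scatter of each other, showed no difference between aryl groups at this position, whereas this change shows that the position can respond beyond the scatter, though only modestly so far. The group that leaves and the group that enters have the same heavy-atom count, and each is one carbon-only aromatic ring without hydrogen-bond donors or acceptors, but nothing measured here bears on why the number falls.

Compound 1 gives > 1000 nM in this assay, which is a limit of the assay and not a number, so its place on the scale stays undefined. On these data alone, it also remains open whether the step belongs to the two methyl groups, their placement or the loss of fluorine, and whether an unsubstituted phenyl, a single methyl, an amine or a carboxylic acid on this aryl ring would keep, extend or lose it.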